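The compounds below may be only part of what the source reports. "The series", "measured", "known", "first", "only" and "open" are said of these compounds alone.

Of the compounds shown here, three built on a shared core have so far been measured in an assay on cells for displacement of a labelled ligand from Glucagon receptor (Homo sapiens), in the presence of a further agent that is not named here; a higher number here means a weaker inhibitor, a lower number a stronger inhibitor. Compound 1 `CCCC(Oc1ccc(-n2cc(OC)cn2)cc1)c1ccc(C(=O)NCCC(=O)O)cc1` gives 4400 nM. Compound 2 `CCCC(Nc1ccc(-n2cc(C(F)(F)F)cn2)nc1)c1ccc(C(=O)NCCC(=O)O)cc1` gives 170 nM. Compound 3 `CCCC(Oc1ccc(-n2cc3ccccc3n2)cc1)c1ccc(C(=O)NCCC(=O)O)cc1` gives 290 nM. On these numbers compound 3 stands second highest of the three: its nearest neighbour is compound 2, a gap that lies within the scatter, and its furthest is compound 1, a gap that lies beyond it. Within the data shown here, the only single-point step among the measured compounds is a 15-fold lower number from compound 1 to compound 3 (1.18 log units; beyond the scatter), a large one.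

Compound 4 `CCCC(Oc1ccc(-n2cc(C(=O)N(C)C)cn2)cc1)c1ccc(C(=O)NCCC(=O)O)cc1` has not yet been measured in this assay. It differs from compound 3 in one place: 4-(dimethylcarbamoyl)-1H-pyrazol-1-yl in place of 2H-indazol-2-yl on an aromatic carbon. The measured step that bears on this change is a 15-fold lower number from compound 1 to compound 3 (1.18 log units; beyond the scatter), in which a substituted pyrazol-1-yl gave way to the indazol-2-yl. Among the measured compounds shown here, compound 4 reverses that exchange, though the pyrazole now carries a dimethylcarbamoyl rather than a methoxy, so the new substituent has no measured counterpart. A return toward a higher number is therefore expected, though its size is uncertain. The step is estimated at a 5.2-fold higher number from compound 3 to compound 4 (0.71 log units; beyond the scatter). Compound 4 is expected to give about 1500 nM, within a range from 450 nM to 5000 nM.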

Compound 4, inhibition constant: 6500 nM
Compound 4: the middle estimate sits 4.3-fold (0.64 log units) below what was measured; the whole stated range lies below it.
By their numbers in this assay, from the lowest: compounds 2 and 3 (each within the scatter of the next); then compounds 1 and 4 (each within the scatter of the next).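

In this assay, 4-(dimethylcarbamoyl)-1H-pyrazol-1-yl in place of 2H-indazol-2-yl on the aromatic carbon para to a large group gives a 22-fold higher number from compound 3 to compound 4 (1.35 log units; beyond the scatter) and is a large step, so a second substituted pyrazole now stands far from the indazole on the weak side, where earlier only the 4-methoxy-1H-pyrazol-1-yl group had been seen to do so. Dimethylcarbamoyl in place of methoxy on the pyrazole gives a 1.5-fold higher number from compound 1 to compound 4 (0.17 log units; within the scatter) and so makes no difference that can be read, even though the entering group is the larger one and carries a carbonyl; across these two substituents the pyrazole compounds stay together, and the gap to the indazole holds for both. Nothing among the data offers an explanation for why the indazole differs so much from these two pyrazoles.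

Whether any pyrazole can match the indazole in this ether series remains open, since only two substituents are shown there, and a methyl, a chlorine, a nitrile or a carboxylic acid at that place could read differently. As far as these compounds go, it is also open whether the unsubstituted pyrazol-1-yl group would sit with compound 1 and compound 4 or nearer to compound 3.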